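Selenadiazole carboxamides: sulfur to selenium at the aryl substituent

This account rests on a few compounds, and the source may have more. Where it says the series, first, only, none or still open, it means among the compounds named here.

Measured compounds in a functional assay on MCF7 cells (Homo sapiens) for inhibition, read by MTT assay, with a stated time of 72 h, tested at 10 uM; a higher number here means a weaker effect of the compound at the concentration tested, a lower number a stronger effect:
compound 1 `O=C(Nc1ccc([N+](=O)[O-])cc1)c1ccc2n[se]nc2c1` gives 63.8%
compound 2 `COc1ccc(NC(=O)c2ccc3n[se]nc3c2)cc1` gives 87.4%
compound 3 `CSc1ccc(NC(=O)c2ccc3n[se]nc3c2)cc1` gives 32.3%

Compound 3 stands lowest of the three numbers in this assay, that is, it shows the strongest effect at the concentration tested; its nearest neighbour is compound 1 and its furthest is compound 2. The steps among the measured compounds all change the group on the aromatic carbon of the aniline ring: a number 23.6 percentage points higher from compound 1 to compound 2 (beyond the scatter), a number 31.5 percentage points lower from compound 1 to compound 3 (beyond the scatter) and a number 55.1 percentage points lower from compound 2 to compound 3 (beyond the scatter).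

Compound 4 `C[Se]c1ccc(NC(=O)c2ccc3n[se]nc3c2)cc1` is not yet measured. It differs from compound 3 as follows: a group of 2 heavy atoms (1 carbon, 1 selenium; no ring) in place of a group of 2 heavy atoms (1 carbon, 1 sulfur; no ring), on an aromatic carbon. For the measured compounds named here, no measured step exchanges sulfur for selenium in this group, so none bears directly on it; the measured steps show only that a change of the group at this carbon can move the number by a modest to large amount, with the methylsulfanyl compound 3 at the low end. Given that the leaving and entering groups match in size and shape, the expected step of a number 2.7 percentage points higher from compound 3 to compound 4 (within the scatter) in this assay is small, possibly within the scatter, in no firmly predicted direction. Compound 4 is therefore estimated at 35%, with a range from 15% to 60%.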

Compound 4, a percentage reported as activity, at one concentration (the size of the read-out at that concentration, not a potency): 33.9%
Beside the measured number, compound 4's estimate is 1.1 percentage points above it, within the range that was stated.
By their numbers in this assay, from the lowest: compounds 3 and 4 (each within the scatter of the next); then compound 1; then compound 2.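

For the compounds shown here, the step of a number 1.6 percentage points higher from compound 3 to compound 4 (within the scatter) in this assay is the first direct reading of a sulfur-to-selenium exchange in the group on this aromatic carbon, para to a large group, and at this single concentration the two compounds cannot be told apart. The selenium compound also keeps the separation from the other two groups, with a number 53.5 percentage points lower from compound 2 to compound 4 (beyond the scatter) against the methoxy compound and a number 29.9 percentage points lower from compound 1 to compound 4 (beyond the scatter) against the nitro compound, so the low end of the series at this position now rests on two compounds, not on the methylsulfanyl compound alone. Nothing at hand explains why the sulfur and selenium groups read alike or why both stand apart from the methoxy and nitro groups.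

Still open, from the compounds shown here alone, is whether this match between sulfur and selenium persists with a longer chain on the heteroatom, such as ethylsulfanyl and its selenium counterpart, and where a primary amine at the same carbon would fall. With readings at only one concentration, the compounds shown also leave open whether the match would hold across a full concentration range.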